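The source may hold more compounds than are shown below. What is called first, only, known or untested is meant among the compounds shown, and "the series" means these compounds.

Measured compounds:
Compound 1, `CN1CCN(c2ccc(C#Cc3c(F)cccc3F)cc2)CC1`: 99.6%
Compound 2, `Fc1cccc(F)c1C#Cc1ccc(-n2cccc2)cc1`: 96.7%

In a functional assay on LS174T cells (Homo sapiens) for inhibition, with a stated time of 4 days, tested at 10 uM (a lower number here means a weaker effect, a higher number a stronger effect of the compound at the concentration tested), compound 1 gives 99.6%, and compound 2 gives 96.7%. For the measured compounds named here, compound 2 has the lower of the two numbers, but the only measured step, a number 2.9 percentage points lower from compound 1 to compound 2 (within the scatter), swapped one group for another on the same aromatic carbon and stayed within the scatter, so the two compounds cannot be told apart on these data. Both values sit close to the top of the percentage scale.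

Compound 3, `Cc1ccc(C)n1-c1ccc(C#Cc2c(F)cccc2F)cc1`, differs from compound 2 by 2,5-dimethyl-1H-pyrrol-1-yl in place of 1H-pyrrol-1-yl on an aromatic carbon. Going by the values given here, this change sits at the same aromatic carbon as the measured step, which is the only evidence that bears on it, and that step was within the scatter. Compound 3 is therefore expected to move by a number 2.7 percentage points lower from compound 2 to compound 3 (within the scatter), no step beyond the scatter. The estimate for compound 3 is 94%, within a range from 82% to 100%.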

Compound 3, a percentage reported as inhibition, at one concentration (the size of the read-out at that concentration, not a potency): 78.8%
Compound 3: the middle estimate sits 15.2 percentage points above what was measured; measured number outside the range, below it.
By their numbers in this assay, from the lowest: compound 3; then compounds 2 and 1 (each within the scatter of the next).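

Within this assay, the group on this aromatic carbon now makes a measurable difference: going from 1H-pyrrol-1-yl to 2,5-dimethyl-1H-pyrrol-1-yl gives a number 17.9 percentage points lower from compound 2 to compound 3 (beyond the scatter) and is the first step here that clears the scatter. The same group in place of 4-methylpiperazin-1-yl gives a number 20.8 percentage points lower from compound 1 to compound 3 (beyond the scatter) even though the two earlier groups could not be told apart, so the position tolerated that first swap but not every group. Nothing measured here accounts for the loss, so the data give no explanation for it.

Going by these compounds, it remains open whether a single methyl group on the pyrrole ring, as in 2-methyl-1H-pyrrol-1-yl, would already lower the number. On these data alone, it is also open whether ethyl groups in place of the two methyl groups would lower it further.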